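The compounds below may be only part of what the source reports. "The series", "measured", "known", "first", "only" and "open" are said of these compounds alone.

Two compounds of the series carry numbers in a functional assay on MCF7 cells (Homo sapiens) for cytotoxicity, read by MTT assay, with a stated time of 48 h; a lower number here means a stronger inhibitor, a higher number a weaker inhibitor. Compound 1, `COc1ccc(COC(=O)/C(=C(\C)NC(N)=O)C(C)c2ccccc2OCc2ccccc2)cc1`, gives 108000 nM. Compound 2, `CCOc1cccc(C(=O)C2=C(O)C(=O)N(Cc3ccco3)C2c2cccnc2)c1`, gives 181000 nM; the gap from compound 1 to compound 2 lies within the scatter, so the two cannot be ranked against each other. No change with a measured step is available. Compound 3, `Cc1ccc(C)c(C(=O)C2=C(O)C(=O)N(Cc3ccco3)C2c2cccnc2)c1`, differs from compound 2 in one place: 2,5-dimethylphenyl in place of 3-ethoxyphenyl on a carbonyl carbon. With nothing measured on that change, no step beyond the scatter is expected from compound 2 to compound 3 in this assay, and the expected step is a 1.0-fold lower number from compound 2 to compound 3 (0.00 log units; within the scatter). Compound 3 is thus estimated at 180000 nM, in the range 60000 nM to 500000 nM.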

Compound 3, half-maximal inhibitory concentration: > 200000 nM
Compound 3 ended at the assay's limit; the forecaster's own chance of this, stated with the estimate: 15%; at least 1.1-fold (0.04 log units) between middle value and limit.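

At this position, on a carbonyl carbon, the series now has its first measured change: 2,5-dimethylphenyl in place of 3-ethoxyphenyl gives an at least 1.1-fold higher number from compound 2 to compound 3 (0.04 log units; that floor lies within the scatter) in this assay. Compound 3 gives a limit of the assay (> 200000 nM) and not a number, so the full size of the step stays unread. That floor does not show that the change matters, and the range left for reading it is narrow: the limit of > 200000 nM in this assay, at which 1 of the 3 values shown sits.

On these data alone, whether an amine or a carboxylic acid on the phenyl ring at this position gives a number clear of the limit remains open. As far as these compounds go, how far compound 3 lies past the limit also remains open.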